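A few compounds are considered here, and "the series" means these few. Any claim that something is new, unique, unknown or untested is made for them only; others in the source may bear on it.

Measured compounds and their values:

compound 1 `ClCc1cccc(Cn2cnc3ncnc(Cl)c32)c1`: 42700 nM
compound 2 `ClCc1ccc(Cn2cnc3nc(Cl)nc(Cl)c32)cc1`: 44700 nM
compound 3 `ClCc1cccc(Cn2cnc3nc(Cl)nc(Cl)c32)c1`: 2810 nM

All three were tested in a functional assay on Hs-578T cells (Homo sapiens) for cytotoxicity, read by sulforhodamine B assay, with a stated time of 48 h; on this read-out lower numbers stand for stronger inhibition of growth and higher numbers for weaker inhibition of growth. Going by the values given here, compound 3 gives 2810 nM and is the one with the lowest number, beyond the usual scatter from both others. Compound 1 gives 42700 nM and compound 2 gives 44700 nM; these two numbers lie within the scatter of each other, so no difference between them can be claimed.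

Compound 1 differs from compound 3 in one place: hydrogen in place of chloro on an aromatic carbon. This change made a 15-fold higher number from compound 3 to compound 1 (1.18 log units; beyond the scatter), so removing that chloro group weakened the inhibition of growth strongly.

Compound 2 and compound 3 have the same atoms joined differently; the difference between their cores is not broken down here.

Compound 4 `ClCc1ccc(Cn2cnc3ncnc(Cl)c32)cc1` has not yet been measured. It differs from compound 2 in one place: hydrogen in place of chloro on an aromatic carbon. Among the compounds with values here, this is the same change as the one from compound 3 to compound 1, at a place described in the same words. If it acts the same way, the number for compound 4 is expected to rise from that of compound 2 by about an 8.9-fold higher number from compound 2 to compound 4 (0.95 log units; beyond the scatter), because the same change gave a 15-fold higher number from compound 3 to compound 1 (1.18 log units; beyond the scatter). Since compound 2 already sits at a high number, the assay may well report only a limit for compound 4. The estimate for compound 4 is 400000 nM, with a range from 80000 nM to 2000000 nM.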

Compound 4, concentration for total growth inhibition: 4260 nM
Beside the measured number, compound 4's estimate is 94-fold (1.97 log units) above it; measured number outside the range, below it.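

In this assay, putting hydrogen in place of chloro on the aromatic carbon between two ring nitrogen atoms gives a 10-fold lower number from compound 2 to compound 4 (1.02 log units; beyond the scatter), so on this core the change strengthened the inhibition of growth, while on the other core it weakened it: the same change on two cores in this assay, a 15-fold higher number (1.18 log units; beyond the scatter) from compound 3 to compound 1 and a 10-fold lower number (1.02 log units; beyond the scatter) from compound 2 to compound 4, 160-fold (2.20 log units) apart, beyond the scatter of two such steps

The effect of this change therefore cannot simply be carried from one core to the other in this series, and the result for one pair of compounds gave a misleading guide to the other pair. Going by these compounds alone, what this does not show is the reason for the reversal: there are only two pairs, tested in a single cell assay, and nothing measured here separates one possible explanation from another.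

The compounds shown leave open how other groups on that same aromatic carbon, such as an amine or a methoxy group, would behave on each of the two cores. They also leave open whether replacing the remaining chloro group on the ring with 2 nitrogen, for example with an amine, would depend on the core in the same way.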